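The compounds below may be only part of what the source reports. "The series", "measured", "known", "first", "only" and "open" are said of these compounds alone.

Working notes on the series. In a functional assay on MCF7 cells (Homo sapiens) for antiproliferative activity, read by MTT assay, with a stated time of 24 h (on this read-out lower numbers stand for stronger inhibition and higher numbers for weaker inhibition), compound 1 `CCn1c(C(=O)N[C@@H](C)C(=O)OC)ccc1C(CC)(CC)c1ccc(OCS(=O)(=O)c2ccccc2)c(C)c1` gives 43700 nM. Compound 2 `CCn1c(C(=O)NCCNC(=O)OC(C)(C)C)ccc1C(CC)(CC)c1ccc(OCS(=O)(=O)c2ccccc2)c(C)c1` reads > 50000 nM, which is a limit of the assay and not a number. Going by the values given here, compound 3 `CCn1c(C(=O)NCCN)ccc1C(CC)(CC)c1ccc(OCS(=O)(=O)c2ccccc2)c(C)c1` gives 6470 nM, the lowest number of the series so far.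

The next change leads to compound 4 `CCN(CC)CCNC(=O)c1ccc(C(CC)(CC)c2ccc(OCS(=O)(=O)c3ccccc3)c(C)c2)n1CC`: diethylamino in place of amino on a saturated chain carbon, two bonds along the chain from an amide-type nitrogen. In words, this is diethylamino in place of amino on a saturated chain carbon, two bonds along the chain from an amide-type nitrogen.

Two measured steps arrive at the 2-aminoethyl amide of compound 3, and both go down: a 6.8-fold lower number from compound 1 to compound 3 (0.83 log units; beyond the scatter) and an at least 7.7-fold lower number from compound 2 to compound 3 (0.88 log units; beyond the scatter). The second of these has only a floor, as compound 2 stands at a limit. Neither step compares substituents on the amino group itself, so they show what is gained by reaching the free amino group, but not what diethyl substitution on it does. Among the compounds with values here, compound 4 keeps a nitrogen at that place, and no measured compound carries the diethylamino group.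

With compound 3 at 6470 nM as the anchor, no step beyond the scatter is expected in this assay, although the uncertainty is wide. The expected change is a 1.1-fold lower number from compound 3 to compound 4 (0.03 log units; within the scatter). Compound 4 is estimated at 6000 nM, with an expected range of 2200 nM to 18000 nM.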

Compound 4, half-maximal inhibitory concentration: 4680 nM
The estimate for compound 4 lay 1.3-fold (0.11 log units) above the measured number, within the range that was stated.
By their numbers in this assay, from the lowest: compounds 4 and 3 (each within the scatter of the next); then compound 1. At a limit, above all of these: compound 2.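

In this assay, going by these compounds alone, replacing amino with diethylamino on the saturated chain carbon, two bonds along the chain from the amide-type nitrogen, gives no step beyond the scatter, which the earlier compounds could not show: a 1.4-fold lower number from compound 3 to compound 4 (0.14 log units; within the scatter). The difference from the methyl ester side chain of compound 1 remains beyond the scatter with the larger group in place, at a 9.3-fold lower number from compound 1 to compound 4 (0.97 log units; beyond the scatter). Compound 2 reads a limit of the assay and not a number, so an at least 10-fold lower number from compound 2 to compound 4 (1.02 log units; beyond the scatter) gives only a floor: the limit of > 50000 nM in this assay, at which 1 of the 4 values shown sits.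

From the compounds shown here alone, what remains open is whether the two ethyl groups can be changed further at this nitrogen, as in a single ethyl group, a piperidine or a morpholine, without a step beyond the scatter. Also open, going by these compounds, is whether the distance from the amide-type nitrogen matters, as a longer chain such as 3-(diethylamino)propyl would test, and whether a carboxylic acid in place of the amine would give a number nearer to that of compound 1.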